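The source may report more compounds than this note shows. Statements on the series, on what has been measured and on what is new or still open speak of the compounds shown alone.

Of the compounds shown here, three built on one shared core have been measured, and a fourth remains open. Compound 1 `COc1ccc2nc(NC(=O)c3cn(-c4ccccc4)nc3-c3ccccc3)sc2c1` carries a methoxy group on the fused ring; in a functional assay on PC-3 cells (Homo sapiens) for cytotoxicity, read by MTT assay, with a stated time of 72 h (on this read-out higher numbers stand for weaker inhibition and lower numbers for stronger inhibition), compound 1 gives 17500 nM. Compound 2 `Cc1ccc2nc(NC(=O)c3cn(-c4ccccc4)nc3-c3ccccc3)sc2c1` differs from compound 1 only by methyl in place of methoxy on an aromatic carbon, and in this assay compound 2 gives 15700 nM. That single change made a 1.1-fold lower number from compound 1 to compound 2 (0.05 log units; within the scatter). Compound 3 `COc1ccc2nc(NC(=O)c3cn(-c4ccccc4)nc3-c3ccc(F)cc3)sc2c1` keeps the methoxy group but differs from compound 1 by fluoro in place of hydrogen on an aromatic carbon; in this assay compound 3 gives 12800 nM. Compound 4 `Cc1ccc2nc(NC(=O)c3cn(-c4ccccc4)nc3-c3ccc(F)cc3)sc2c1` has not yet been measured. It differs from compound 3 by methyl in place of methoxy on an aromatic carbon, which is the same change already seen between compound 1 and compound 2, at the same place on the core. Because that change gave a 1.1-fold lower number from compound 1 to compound 2 (0.05 log units; within the scatter), only a small step is expected here as well. Compound 4 is expected to make a 1.1-fold lower number from compound 3 to compound 4 (0.05 log units; within the scatter). In this assay compound 4 is therefore estimated to give about 11500 nM, most likely falling between 6000 nM and 22000 nM.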

Compound 4, half-maximal inhibitory concentration: 20500 nM
Estimate against measurement, compound 4: 1.8-fold (0.25 log units) below; the range from low to high includes it.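

In this assay, methyl in place of methoxy on the fluoro-bearing core gives a 1.6-fold higher number from compound 3 to compound 4 (0.20 log units; within the scatter), and fluoro in place of hydrogen on the methyl-bearing core gives a 1.3-fold higher number from compound 2 to compound 4 (0.12 log units; within the scatter). These four compounds give no sign that the methyl change depends on the core, but with steps this small they cannot show that it carries over unchanged either: the same change on two cores in this assay, a 1.1-fold lower number (0.05 log units; within the scatter) from compound 1 to compound 2 and a 1.6-fold higher number (0.20 log units; within the scatter) from compound 3 to compound 4, 1.8-fold (0.25 log units) apart, within the scatter of two such steps

The fluoro change reads the same way, with neither a dependence on the core nor a firm carry-over established: the same change on two cores in this assay, a 1.4-fold lower number (0.14 log units; within the scatter) from compound 1 to compound 3 and a 1.3-fold higher number (0.12 log units; within the scatter) from compound 2 to compound 4, 1.8-fold (0.25 log units) apart, within the scatter of two such steps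

On these data alone, what stays open is whether any group at these two places can move the number beyond the usual scatter of the measurement. An amine or a carboxylic acid in place of the methyl, or a chloro group in place of the fluoro, could show whether a change carries from one core to the other when the step itself is large enough to read.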